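The compounds below may be only part of what the source reports. "The series", "measured", "known", "first", "only" and "open" are said of these compounds alone.

Measured in a functional assay on HeLa cells (Homo sapiens) for inhibition; a lower number here means a stronger inhibitor, a higher number a weaker inhibitor:
compound 1, `Oc1cccc(-c2cc(-c3ccc(F)cc3)cc(-c3ccccc3O)n2)c1`: a limit, > 50000 nM
compound 2, `Oc1cccc(-c2cc(-c3ccc(F)cc3)cc(-c3cccc(O)c3)n2)c1`: 1280 nM
compound 3, `Oc1ccc(-c2cc(-c3ccc(F)cc3)cc(-c3cccc(O)c3)n2)cc1`: 8080 nM

Compound 1 sits at the limit of > 50000 nM in this assay, at which 1 of the 3 values shown sits; its value is a limit of the assay, not a number. Among the two numbers, compound 2 holds the lowest; compound 3 is nearest, with a 6.3-fold higher number from compound 2 to compound 3 (0.80 log units; beyond the scatter). The steps away from compound 1, an at least 39-fold lower number from compound 1 to compound 2 (1.59 log units; beyond the scatter) and an at least 6.1-fold lower number from compound 1 to compound 3 (0.79 log units; beyond the scatter), each move a hydroxyl on one of the phenyl groups and touch nothing else on the shared core.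

Compound 4, `Oc1cccc(-c2cc(-c3cccc(C(F)(F)F)c3)cc(-c3cccc(O)c3)n2)c1`, differs from compound 2 in the group that sits meta to the two 3-hydroxyphenyl groups, opposite the ring nitrogen: 3-(trifluoromethyl)phenyl in place of 4-fluorophenyl on an aromatic carbon. For the measured compounds named here, none of the measured steps alters this group; all three concern a hydroxyphenyl group, so the series gives no direct guide to the size or direction of this step in this assay. With nothing to rest on, the expectation is a change within the scatter, direction open, with a range widened to reflect the lack of precedent. Compound 4 is therefore estimated at 1500 nM, between 400 nM and 6000 nM. The expected step is a 1.2-fold higher number from compound 2 to compound 4 (0.07 log units; within the scatter).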

Compound 4, half-maximal inhibitory concentration: 12700 nM
The estimate for compound 4 lay 8.5-fold (0.93 log units) below the measured number; the measured number lies above the stated range.
By their numbers in this assay, from the lowest: compound 2; then compounds 3 and 4 (each within the scatter of the next). At a limit, above all of these: compound 1.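

In this assay, for the compounds shown here, the group opposite the ring nitrogen proves able to move the number: 3-(trifluoromethyl)phenyl in place of 4-fluorophenyl gives a 9.9-fold higher number from compound 2 to compound 4 (1.00 log units; beyond the scatter), with both 3-hydroxyphenyl groups left unchanged, whereas the earlier steps concerned only a hydroxyphenyl group. Going by these compounds alone, this exchange alters both the substituent and its place on the phenyl group, so the single step cannot be divided between the two changes. Nothing in the available measurements bears on why the number rises at this position.

Open, as far as these compounds go, is how much of the step belongs to trifluoromethyl replacing fluorine and how much to the shift of place on the phenyl group, and whether the same step would appear with the hydroxyl arrangement of compound 3. Also open, from the compounds shown here alone, is how this position responds to a phenyl group carrying an amine or a carboxylic acid, and whether any group here gives a lower number than compound 2, at 1280 nM.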